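Adding a (methylsulfanyl)methyl group to compound 1

This account rests on a few compounds, and the source may have more. Where it says the series, first, only, none or still open, it means among the compounds named here.

Measured so far in an ADME assay on HepG2 cells (Homo sapiens) for cytotoxicity, read by MTT assay, with a stated time of 72 h; a lower number here means that less compound is tolerated, a higher number that more compound is tolerated
Compound 1 `O=[N+]([O-])c1cnc2c(Br)cc(Cl)cn12` gives 16200 nM
Compound 2 `O=[N+]([O-])c1c(CS(=O)(=O)c2ccccc2)nc2c(Br)cc(C(F)(F)F)cn12` gives > 15600 nM (a limit)
Compound 3 `CS(=O)(=O)Cc1nc2c(Sc3ccc(Cl)cc3)cc(Cl)cn2c1[N+](=O)[O-]` gives > 31200 nM (a limit)

Going by the values given here, compound 1 stands alone in this set, since its reading of 16200 nM is the only actual number among the three. The entry for compound 2 (> 15600 nM) is a limit of the assay and not a number. The entry for compound 3 (> 31200 nM) is likewise a limit.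

The next compound to be tested is compound 4 `CSCc1nc2c(Br)cc(Cl)cn2c1[N+](=O)[O-]`. It carries (methylsulfanyl)methyl in place of hydrogen on an aromatic carbon of the core of compound 1, next to the ring atom that bears a nitro group ((methylsulfanyl)methyl in place of hydrogen on an aromatic carbon).

Among the compounds with values here, no measured pair isolates a change of this kind, so the expectation rests on little. The anchor is compound 1 with its 16200 nM in this assay. The step expected a 1.2-fold higher number from compound 1 to compound 4 (0.07 log units; within the scatter) is none beyond the usual scatter, with a slight lean toward more compound being tolerated. For compound 4 the estimated value is 19000 nM. The expected range for compound 4 runs from 8000 nM to 45000 nM.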

Compound 4, half-maximal cytotoxic concentration: > 15600 nM
Compound 4 gave a limit, no number; the forecaster's own chance of this, stated with the estimate: 40%; the middle value lies beyond the limit too.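

In this assay compound 4 gives > 15600 nM, which is a limit of the assay and not a number, so the step from compound 1 to compound 4 cannot be read. The compounds shown leave open whether (methylsulfanyl)methyl in place of hydrogen on an aromatic carbon changes how much compound is tolerated.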